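Compound 3 in the Vero cytotoxicity series: dropping the thiophene methyl

The compounds below may be only part of what the source reports. "The series", "measured", "known", "first", "only" and "open" are said of these compounds alone.

- compound 1 `COc1cc(NCc2ccc(C)o2)ccc1-c1cnco1` gives 45200 nM in an ADME assay on Vero cells (Chlorocebus sabaeus) for cytotoxicity, read by MTT assay, with a stated time of 96 h; on this read-out lower numbers stand for higher toxicity in this test and higher numbers for lower toxicity in this test
- compound 2 `COc1ccc(-c2cnco2)cc1NCc1ccc(C)s1` gives 42700 nM in this assay

Compound 2 stands within the scatter of compound 1, so the two values cannot be told apart. The step to compound 3 `COc1ccc(-c2cnco2)cc1NCc1cccs1` puts hydrogen in place of methyl on an aromatic carbon next to the ring sulfur, turning 5-methylthiophen-2-yl into thiophen-2-yl. Among the measured compounds shown here, no measured pair isolates this change. The estimated 1.2-fold higher number from compound 2 to compound 3 (0.07 log units; within the scatter) is expected to stay within the scatter in this assay with no clear direction. Compound 3 is estimated at 50000 nM with an expected range of 24000 nM to 100000 nM in this assay overall.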

Compound 3, half-maximal cytotoxic concentration: 53800 nM
The estimate for compound 3 lay 1.1-fold (0.03 log units) below the measured number; the measured number falls inside the stated range.
By their numbers in this assay, from the lowest: compounds 2, 1 and 3 (each within the scatter of the next).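

Among the compounds shown here, the first measured step at this position, 5-methylthiophen-2-yl to thiophen-2-yl, is a 1.3-fold higher number from compound 2 to compound 3 (0.10 log units; within the scatter) in this assay. Either methyl or hydrogen on this aromatic carbon next to the ring sulfur is therefore compatible with values that cannot be told apart in this assay. Nothing available explains this result.

Still open, going by these compounds, is whether a larger or charged group here, such as an ethyl chain, an amine or a carboxylic acid, would take the number beyond the scatter. The compounds shown also leave open whether hydrogen in place of methyl reads the same on another ring.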